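This account rests on a few compounds, and the source may have more. Where it says the series, first, only, none or still open, it means among the compounds named here.

Compound 1 `O=C(Nc1cc(F)c(F)c(F)c1)N1Cc2c(-c3ccc(F)cc3F)cnn2CC1C1CC1` is the only one of the three measured compounds to give a number in a toxicity assay on HepG2 2.2.15 cells (Homo sapiens) for cytotoxicity, read by CellTiter-Glo; on this read-out lower numbers stand for higher toxicity in this test and higher numbers for lower toxicity in this test: compound 1 gives 32100 nM. Compound 2 `C[C@H]1Cn2ncc(N3CC(c4ccccc4)CC3=O)c2CN1C(=O)NCc1cc(F)c(F)c(F)c1` reaches only a limit of the assay, > 2000 nM. Compound 3 `C[C@H]1Cn2ncc(N3CC(c4ccccc4)CC3=O)c2CN1CC(=O)Nc1cc(F)c(F)c(F)c1` likewise reaches only a limit, > 2000 nM. Among the measured compounds shown here, the single number thus stands against (the limit of > 2000 nM in this assay, at which 2 of the 3 values shown sit). Compound 4 `O=C1c2ccccc2CN1c1cnn2c1CN(C(=O)Nc1cc(F)c(F)c(F)c1)C(C1CC1)C2` differs from compound 1 in one place (a group of 10 heavy atoms (8 carbon, 1 nitrogen, 1 oxygen; one five-membered non-aromatic ring with 1 hetero atom, one six-membered aromatic ring of carbon only) in place of a group of 8 heavy atoms (6 carbon, 2 fluorine; one six-membered aromatic ring of carbon only), on an aromatic carbon). For the measured compounds named here, no step between measured compounds is available to calibrate this change, so the shift in this assay is expected to stay within the usual scatter, in no preferred direction. Compound 4 is therefore estimated at 25000 nM, with a range from 8000 nM to 60000 nM. This estimate means an expected step of a 1.3-fold lower number from compound 1 to compound 4 (0.11 log units; within the scatter).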

Compound 4, half-maximal cytotoxic concentration: 38500 nM
Compound 4: the middle estimate sits 1.5-fold (0.19 log units) below what was measured; measured number inside the range.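

In this assay, among the compounds shown here, the step of a 1.2-fold higher number from compound 1 to compound 4 (0.08 log units; within the scatter) is the first calibration at this position, and it lies within the scatter. On this aromatic carbon, 2,4-difluorophenyl can thus give way to a larger group containing a five-membered non-aromatic ring and 1 hydrogen-bond acceptor with no readable shift in this read-out.

On these data alone, whether an amine or a carboxylic acid at this position would leave the number equally unmoved stays open. Compound 2 and compound 3 offer no further comparison, as each gives only a limit of the assay: the limit of > 2000 nM in this assay, at which 2 of the 4 values shown sit.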